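Pyridin-2-yl in place of pyridin-3-yl on compound 1

The compounds below may be only part of what the source reports. "The series", "measured", "known", "first", "only" and "open" are said of these compounds alone.

Among the compounds with values here, in a functional assay on RPMI 8402 cells (Homo sapiens) for cytotoxicity (a higher number here means a weaker inhibitor, a lower number a stronger inhibitor), compound 1 `c1cncc(-c2ccc3[nH]c(-c4ccc5[nH]c(-c6ccc7[nH]cnc7c6)nc5c4)nc3c2)c1` gives 35 nM, the only exact number available. Compound 2 `N#Cc1ccc2[nH]c(-c3ccc4[nH]cnc4c3)nc2c1` is reported only as a limit, > 25000 nM. Compound 3 `c1ccc(-c2ccc3[nH]c(-c4ccc5[nH]c(-c6ccc7[nH]cnc7c6)nc5c4)nc3c2)nc1` has the same atoms as compound 1, joined differently, with pyridin-2-yl in place of pyridin-3-yl on an aromatic carbon. Within the data shown here, no measured pair tests this swap, and the shared core stays untouched. The expected step of a 1.7-fold higher number from compound 1 to compound 3 (0.23 log units; within the scatter) therefore leans slightly towards weaker inhibition, with nothing beyond the usual scatter anticipated. For compound 3, the estimated value is 60 nM, within a range of 15 nM to 300 nM.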

Compound 3, half-maximal inhibitory concentration: 160 nM
Beside the measured number, compound 3's estimate is 2.7-fold (0.43 log units) below it, and the stated range covers the measured number.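

In this assay, pyridin-2-yl in place of pyridin-3-yl brings a 4.6-fold higher number from compound 1 to compound 3 (0.66 log units; beyond the scatter) and so shows that this position responds to where the ring nitrogen sits, even with the same atoms. The earlier compounds shown here offered no comparison of this kind, since they differ in more than one place. Nothing given here bears on why the step occurs.

Going by these compounds, whether pyridin-4-yl, a plain phenyl ring or an amine-bearing ring at this position would fall nearer compound 1 or compound 3 remains open.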